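The compounds below may be only part of what the source reports. "The series", "measured", "known", "first", "only" and "open" are said of these compounds alone.

Measured compounds in a functional assay on SGC-7901 cells (Homo sapiens) for cytotoxicity, read by MTT assay, with a stated time of 48 h; a lower number here means a stronger inhibitor, a higher number a weaker inhibitor:
Compound 1 `CCN(CC)c1ccc2cc(C(=O)c3ccc(N4CCN(C(=O)CN5CCN(S(=O)(=O)c6ccc(C#N)cc6)CC5)CC4)cc3)oc2c1` gives > 40000 nM, a limit of the assay.
Compound 2 `C#CCN1CCN(CC(=O)N2CCN(c3ccc(C(=O)c4cc5ccc(N(CC)CC)cc5o4)cc3)CC2)CC1` gives 20100 nM.
Compound 3 `CCOC(=O)CN1CCN(CC(=O)N2CCN(c3ccc(C(=O)c4cc5ccc(N(CC)CC)cc5o4)cc3)CC2)CC1` gives > 40000 nM, also a limit.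

Compound 3 thus stands at the top of the series, beside compound 1, both at the limit of > 40000 nM in this assay, at which 2 of the 3 values shown sit; only compound 2 returns a number. Compound 4 `CCN(CC)c1ccc2cc(C(=O)c3ccc(N4CCN(C(=O)CN5CCN(CC(C)=O)CC5)CC4)cc3)oc2c1` differs from compound 3 by methyl in place of ethoxy on a carbonyl carbon. Going by the values given here, no measured step touches the carbonyl carbon itself. The nearest, an at least 1.9-fold higher number from compound 2 to compound 3 (0.29 log units; that floor lies within the scatter), changes the substituent on the chain carbon one bond in, and a step that the two limits leave unreadable from compound 1 to compound 3 cannot be read. Neither tests ester against ketone, so no step beyond the scatter is expected. Compound 4 is therefore estimated at 40000 nM, between 15000 nM and 100000 nM, most likely again a limit. The expected step is a number no higher from compound 3 to compound 4 (the limit leaves the size open).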

Compound 4, half-maximal inhibitory concentration: 2210 nM
The estimate for compound 4 lay 18-fold (1.26 log units) above the measured number; measured number below the stated range.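

Methyl in place of ethoxy on a carbonyl carbon gives an at least 18-fold lower number from compound 3 to compound 4 (1.25 log units; beyond the scatter), so this small exchange at the end of the side chain carries real weight, where no earlier step could be read beyond the scatter. The 2-oxopropyl group also stands apart from the other two substituents, with a 9.1-fold lower number from compound 2 to compound 4 (0.96 log units; beyond the scatter) and an at least 18-fold lower number from compound 1 to compound 4 (1.25 log units; beyond the scatter). Two of these three steps are floors only: the limit of > 40000 nM in this assay, at which 2 of the 4 values shown sit.

Still open, on these data alone, is whether a longer ketone chain, a carboxylic acid or an amide on the same saturated chain carbon would keep the number of compound 4.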